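Taking the nitro group off compound 3

The source may report more compounds than this note shows. Statements on the series, on what has been measured and on what is new or still open speak of the compounds shown alone.

In an ADME assay on H9 cells (Homo sapiens) for cytotoxicity, read by XTT assay, with a stated time of 6 days (a lower number here means that less compound is tolerated, a higher number that more compound is tolerated), compound 3 (`Cc1cc(C#N)cc(C)c1Oc1cc(Nc2ccc(C#N)cc2)c(N)cc1[N+](=O)[O-]`) gives 62700 nM. Compound 1 (`Cc1cc(C#N)cc(C)c1Oc1cc(Nc2ccc(C#N)cc2)c(N)cc1N`) gives 51000 nM and compound 2 (`Cc1cc(Br)cc(C)c1Oc1ccc(N)c(Nc2ccc(C#N)cc2)c1`) gives 44600 nM, so all three numbers lie within the scatter of one another. Compound 4 (`Cc1cc(C#N)cc(C)c1Oc1ccc(N)c(Nc2ccc(C#N)cc2)c1`) follows from compound 3 by hydrogen in place of nitro on an aromatic carbon, para to a (4-cyanophenyl)amino group. Among the measured compounds shown here, one measured step bears on this carbon, nitro in place of amino: a 1.2-fold higher number from compound 1 to compound 3 (0.09 log units; within the scatter). This is a single small step, so no change beyond the scatter is expected in this assay. The expected step is a 1.3-fold lower number from compound 3 to compound 4 (0.10 log units; within the scatter). For compound 4 the estimated value is 50000 nM, with an expected range of 25000 nM to 100000 nM.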

Compound 4, half-maximal cytotoxic concentration: 49800 nM
The estimate for compound 4 lay 1.0-fold (0.00 log units) above the measured number; the range from low to high includes it.
By their numbers in this assay, from the lowest: compounds 2, 4, 1 and 3 (each within the scatter of the next).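

With hydrogen, amino and nitro now all seen on this carbon in this assay, the position shows no change beyond the scatter: a 1.3-fold lower number from compound 3 to compound 4 (0.10 log units; within the scatter) and a 1.0-fold lower number from compound 1 to compound 4 (0.01 log units; within the scatter) both stay within it. Cyano in place of bromo on an aromatic carbon, a 1.1-fold higher number from compound 2 to compound 4 (0.05 log units; within the scatter), also stays within the scatter. No measured evidence accounts for these small steps. On these data alone, whether a carboxylic acid or a longer chain on this carbon would move the number beyond the scatter remains open, as does whether the same holds in other cell types.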